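Series notes: lipophilicity step from compound 3 to compound 4

The source may report more compounds than this note shows. Statements on the series, on what has been measured and on what is new or still open speak of the compounds shown alone.

Of the compounds shown here, three have been measured in a physicochemical assay for lipophilicity; on this read-out higher numbers stand for higher lipophilicity and lower numbers for lower lipophilicity. Compound 1 `C[C@H]1CC[C@@H]2[C@@H](OC(=O)[C@]23CC(c2ccccc2[N+](=O)[O-])=NO3)[C@]2(C)C(=O)C=C[C@@]12O` gives 1.37, and compound 2 `C[C@H]1CC[C@@H]2[C@@H](OC(=O)[C@]23CC(c2ccc([N+](=O)[O-])cc2)=NO3)[C@]2(C)C(=O)C=C[C@@]12O` gives 1.37; between them no change at the digits printed from compound 1 to compound 2 (within the scatter). Compound 3 `C[C@H]1CC[C@@H]2[C@@H](OC(=O)[C@]23CC(c2ccc(Cl)cc2)N(c2ccccc2)O3)[C@]2(C)C(=O)C=C[C@@]12O` gives 3.87, the highest of the three numbers, standing beyond the scatter above both compound 1 and compound 2, which lie far below it and close to each other.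

Compound 4 `C[C@H]1CC[C@@H]2[C@@H](OC(=O)[C@]23CC(c2ccccc2F)N(c2ccccc2)O3)[C@]2(C)C(=O)C=C[C@@]12O` has not yet been measured. It differs from compound 3 in one place: 2-fluorophenyl in place of 4-chlorophenyl on a saturated ring carbon. For the measured compounds named here, no measured step exchanges a chlorine for a fluorine on a phenyl group, and none moves a substituent on the phenyl group that sits on this saturated ring carbon, so no step bears directly on the change. Going by the values given here, the only step in hand, between compound 1 and compound 2, moved a nitro group around a phenyl ring held on a carbon with a double bond to nitrogen and gave nothing beyond the scatter, but it concerns a different group in a different place. The step of a number 0.47 log units lower from compound 3 to compound 4 (beyond the scatter) is therefore expected to be modest, most likely downward, and a result within the scatter of compound 3 cannot be excluded. Compound 4 is estimated at 3.4, with a range from 2.9 to 3.9.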

Compound 4, partition coefficient: 3.35
For compound 4 the middle estimate is 0.05 log units above the measured one; the range from low to high includes it.
By their numbers in this assay, from the lowest: compounds 1 and 2 (each within the scatter of the next); then compound 4; then compound 3.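

In this assay, the saturated ring carbon next to the ring nitrogen now has its first reading for a change of aryl group: replacing 4-chlorophenyl with 2-fluorophenyl gives a number 0.52 log units lower from compound 3 to compound 4 (beyond the scatter). The leaving and entering groups have the same heavy-atom count, and neither has a hydrogen-bond donor or acceptor, so the step appears without any difference in those computed counts. No supporting data are available to explain the step at this position.

The change swaps the halogen and alters the substituted position on the phenyl group at once, and no compound shown changes only one of these, so their separate contributions remain open. Also open, as far as these compounds go, is how this read-out would respond to an amine, a carboxylic acid or a longer chain on that phenyl group, or to replacing the phenyl group on the ring nitrogen with a different group.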